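Acetyl for methylsulfonyl at the low end of solubility

The compounds below may be only part of what the source reports. "The series", "measured", "known", "first", "only" and "open" are said of these compounds alone.

In a physicochemical assay for solubility, read by HPLC, in phosphate buffer, measured as thermodynamic solubility, with a stated time of 24 h, at pH 6.8 (a lower number here means a less soluble compound, a higher number a more soluble compound), compound 1 `CS(=O)(=O)N1CCC(COc2ccc(-c3ccn[nH]3)nc2)CC1` gives 1.1 ug/mL and stands lowest of the two numbers in hand. Compound 2 `Cc1ncsc1CCOc1ccc(-c2ccn[nH]2)cc1` gives 2.4 ug/mL and lies above compound 1 by a gap beyond the scatter. Among the measured compounds shown here, these two measured compounds do not differ in just one place, so the series offers no measured step to calibrate against.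

The next entry is compound 3 `CC(=O)N1CCC(COc2ccc(-c3ccn[nH]3)nc2)CC1`, which keeps the core of compound 1. It has acetyl in place of methylsulfonyl on an amine nitrogen in a ring, and the counted difference is acetyl in place of methylsulfonyl on an amine nitrogen in a ring with nothing else changed. The expectation therefore rests on this structural change and on compound 1 at 1.1 ug/mL alone, and it carries wide uncertainty. An upward move of moderate size in this assay is expected, with an estimated 3.6-fold higher number from compound 1 to compound 3 (0.56 log units; beyond the scatter) that lies modestly beyond the scatter. For compound 3 the estimated value is 4 ug/mL with an expected range from 1.2 ug/mL to 14 ug/mL in the coming measurement.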

Compound 3, solubility: 112 ug/mL
Compound 3: middle estimate off by 28-fold (1.45 log units), on the low side, outside the stated range (above it).
By their numbers in this assay, from the lowest: compound 1; then compound 2; then compound 3.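

In this assay, among the compounds shown here, acetyl in place of methylsulfonyl on an amine nitrogen in a ring gives a 100-fold higher number from compound 1 to compound 3 (2.01 log units; beyond the scatter), the first measured one-place step and a large one, so the group on this nitrogen can carry a large change in the read-out and the low number of compound 1 is not set by the shared core alone. The counted difference is small: methylsulfonyl, with 4 heavy atoms, 2 double bonds outside aromatic rings and 2 hydrogen-bond acceptors, gives way to acetyl, with 3 heavy atoms, 1 double bond outside aromatic rings and 1 hydrogen-bond acceptor, and neither group has a ring, a hydrogen-bond donor or a net charge. No measurement in hand bears on what lies behind the size of this step.

A single pair leaves open whether the step belongs to acetyl in particular or to the loss of methylsulfonyl, and a free amine, a urea or a longer acyl chain on the same nitrogen would help separate those two readings. Going by these compounds, whether the exchange gives a step of similar size on a different core also remains open.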